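The source may hold more compounds than are shown below. What is called first, only, known or untested is meant among the compounds shown, and "the series" means these compounds.

Measured in a functional assay on brain (Rattus norvegicus, strain Wistar) for inhibition; a lower number here means a stronger inhibitor, a higher number a weaker inhibitor:
- compound 1 `CCCCCc1ccc(-c2c(C)[nH]c(=O)n2C)cc1`: 5900 nM
- compound 2 `CCCCCCCCCCCCCCc1ccc(-c2c(C)[nH]c(=O)n2C)cc1`: 43800 nM

Compound 2 has the higher of the two numbers, which makes it the weaker inhibitor in this assay. Compound 3 `CCCCCCCCCCCCCCc1ccc(-c2c(C)[nH]c(=O)n2C2CCCCC2)cc1` keeps the chain of compound 2 but carries cyclohexyl in place of methyl on an aromatic nitrogen. Within the data shown here, the only measured step, a 7.4-fold higher number from compound 1 to compound 2 (0.87 log units; beyond the scatter), was modest and concerns the chain, so it gauges size only. No substituent on the aromatic nitrogen has yet been compared, and the data give no direction. The central expectation is therefore no change beyond the scatter, although a shift of similar modest size either way would not be surprising. The expected step is a 1.1-fold lower number from compound 2 to compound 3 (0.04 log units; within the scatter). The estimated value for compound 3 is 40000 nM, with an expected range of 12000 nM to 130000 nM.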

Compound 3, half-maximal inhibitory concentration: > 100000 nM
Compound 3: only a limit was reported; the forecaster's own chance of this, stated with the estimate: 25%; at least 2.5-fold (0.39 log units) between middle value and limit.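

Among these compounds, on the aromatic nitrogen, the first comparison at this position in this assay gives an at least 2.2-fold higher number from compound 2 to compound 3 (0.35 log units; beyond the scatter), so cyclohexyl in place of methyl moves the chain-bearing compound 2 towards weaker inhibition. Until now only the chain had been varied, and this step shows that the substituent on the aromatic nitrogen also matters, at least on this long chain. The value for compound 3 is a limit, so this step has a lower bound and no measured size: the limit of > 100000 nM in this assay, at which 1 of the 3 values shown sits.

As far as these compounds go, whether the loss goes with the ring or with the added carbons remains open, and a phenyl or an ethyl on the aromatic nitrogen would help to separate the two. Also open, from the compounds shown here alone, is whether cyclohexyl in place of methyl acts in the same direction on the shorter chain of compound 1.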